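Swapping the ring on the carbonyl of compound 3

A few compounds are considered here, and "the series" means these few. Any claim that something is new, unique, unknown or untested is made for them only; others in the source may bear on it.

Measured compounds:
compound 1 `CC(C)(C)c1cc(NC(=O)[C@@H]2CCCCN2CC2CC2)no1` — 0.15 h
compound 2 `CC(C)CN1CCCC[C@H]1C(=O)Nc1cc(C(C)(C)C)on1` — 0.1 h
compound 3 `CC(C)(C)c1cc(NC(=O)[C@@H]2CCCCN2C(=O)C2CCCCC2)no1` — 0.483 h

All three share one core and differ only in the group on the amine nitrogen in the ring. In an ADME assay (liver) for metabolic stability, with Liver microsome (Homo sapiens) as the target, read by LC-MS, using microsomes and NADPH, tested at 1 uM (a lower number here means that the compound disappears faster, a higher number that the compound lasts longer), compound 3 stands highest of the three; the nearest number is that of compound 1, and the step of a 3.2-fold higher number from compound 1 to compound 3 (0.51 log units; beyond the scatter) lies beyond the scatter, as does a 4.8-fold higher number from compound 2 to compound 3 (0.68 log units; beyond the scatter). Between compound 1 and compound 2 the step of a 1.5-fold lower number from compound 1 to compound 2 (0.18 log units; within the scatter) is within the scatter.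

Compound 4 `CC(C)(C)c1cc(NC(=O)[C@@H]2CCCCN2C(=O)N2CC[S+]([O-])CC2)no1` keeps the carbonyl on that ring nitrogen but changes what sits on it: a group of 7 heavy atoms (4 carbon, 1 nitrogen, 1 oxygen, 1 sulfur; one six-membered non-aromatic ring with 2 hetero atoms) in place of a group of 6 heavy atoms (6 carbon; one six-membered non-aromatic ring of carbon only), on a carbonyl carbon

Among the measured compounds shown here, no measured step covers this kind of exchange. The two steps that go beyond the scatter, a 3.2-fold higher number from compound 1 to compound 3 (0.51 log units; beyond the scatter) and a 4.8-fold higher number from compound 2 to compound 3 (0.68 log units; beyond the scatter), concern replacing an alkyl group on the ring nitrogen by a carbonyl-bearing group, and compound 4 retains that carbonyl. The measured compounds give no guide to what follows from the ring swap on the carbonyl carbon, so the expectation rests on compound 3 alone, with a wide range around it. Compound 4 is expected to give about 0.6 h in this assay, between 0.25 h and 1.5 h, which would mean a step of a 1.2-fold higher number from compound 3 to compound 4 (0.09 log units; within the scatter) that is expected to stay within the scatter.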

Compound 4, half-life: > 2 h
Compound 4: no number, only a limit; the forecaster's own chance of this, stated with the estimate: 10%; middle value at least 3.3-fold (0.52 log units) from the limit.
By their numbers in this assay, from the lowest: compounds 2 and 1 (each within the scatter of the next); then compound 3. At a limit, above all of these: compound 4.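

The earlier compounds shown here showed a change beyond the scatter only when an alkyl group on the ring nitrogen gave way to a carbonyl-bearing group. Compound 4 shows that with the carbonyl kept, the group on the carbonyl carbon still matters, with an at least 4.1-fold higher number from compound 3 to compound 4 (0.61 log units; beyond the scatter) when cyclohexyl gives way to the new ring with its 2 hetero atoms. Set against the alkyl groups on the amine nitrogen in the ring, the whole new group gives an at least 20-fold higher number from compound 2 to compound 4 (1.30 log units; beyond the scatter) and an at least 13-fold higher number from compound 1 to compound 4 (1.12 log units; beyond the scatter) as large steps, and in this assay compound 4 has no exact number, only a limit: the limit of > 2 h in this assay, at which 1 of the 4 values shown sits.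

The nitrogen, the sulfur and the oxygen on that sulfur all enter together, and the compounds shown cannot separate what each contributes to the step. They also leave open how a longer chain, an amine or a carboxylic acid on that carbonyl carbon would behave in this assay and whether the gain from this ring would carry over to a different core.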